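The compounds below may be only part of what the source reports. "The series", "measured", "known", "first", "only" and "open" are said of these compounds alone.

Measured so far:
compound 1 `CCCN(CC(=O)N(C)C)c1nc(C)nc2c1c(C)nn2-c1ccc(OC)cc1C`, 1410 nM;
compound 2 `CCCNCc1nnc(Nc2nc(C)nc3c2c(C)nn3-c2ccc(OC)cc2C)o1`, 996 nM;
compound 3 `CCC(CC)Nc1nc(C)nc2c1c(C)nn2-c1ccc(OC)cc1C`, 42 nM.

All three share one core and differ in the group on its amine-bearing aromatic carbon. In a functional assay on CHO cells for antagonist activity at corticotropin-releasing factor receptor 1 (Homo sapiens), read by cAMP accumulation (on this read-out higher numbers stand for weaker inhibition and lower numbers for stronger inhibition), compound 3 gives the lowest number of the three. The measured steps both lead to it: a 34-fold lower number from compound 1 to compound 3 (1.53 log units; beyond the scatter) and a 24-fold lower number from compound 2 to compound 3 (1.38 log units; beyond the scatter). Both steps swap a large, heteroatom-rich substituent for the small pentan-3-yl group, and both are large.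

Compound 4 `CCC(CC)Nc1nc(C)nc2c1cnn2-c1ccc(OC)cc1C` keeps the pentan-3-ylamino group of compound 3 unchanged and alters the core instead: hydrogen in place of methyl on an aromatic carbon. Going by the values given here, neither measured step touches this part of the molecule, so there is no direct precedent for it among the three compounds. The change removes one carbon and leaves everything else in place. Without a step of this kind to lean on, the expectation is a small change at most, and the step from compound 3 to compound 4 is estimated at a 1.9-fold higher number from compound 3 to compound 4 (0.28 log units; within the scatter), which may well fall within the scatter.

For compound 4 in this assay the estimate is 80 nM, with a range from 25 nM to 300 nM.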

Compound 4, inhibition constant: 85 nM
The estimate for compound 4 lay 1.1-fold (0.03 log units) below the measured number; low and high end bracket the measured number.
By their numbers in this assay, from the lowest: compound 3; then compound 4; then compounds 2 and 1 (each within the scatter of the next).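

Going by these compounds alone, the three earlier compounds varied only the group on the amine-bearing aromatic carbon, so compound 4 gives the first look at the methyl on the five-membered aromatic ring of the shared core. In this assay, putting hydrogen in place of that methyl gives a 2.0-fold higher number from compound 3 to compound 4 (0.31 log units; beyond the scatter), a modest step that is nonetheless printed as beyond the scatter, so this single carbon has a measurable link to the read-out, though a smaller one than the large swap of the amine-bearing group seen in a 34-fold lower number from compound 1 to compound 3 (1.53 log units; beyond the scatter). Nothing measured here says why losing this methyl weakens inhibition, and no supporting data on the cause are available.

This one pair covers only methyl and hydrogen at this position, so it leaves open whether ethyl, a longer chain, or a chlorine atom there would give a lower or a higher number than compound 3 at 42 nM. It also leaves open whether the same swap would have a similar size with another amine group, such as the ((dimethylcarbamoyl)methyl)(propyl)amino group of compound 1, in place of pentan-3-ylamino.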